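The source may hold more compounds than are shown below. What is called first, only, known or untested is meant among the compounds shown, and "the series" means these compounds.

Working notes on a small thiazole-ester series assessed in a toxicity assay on THLE-2 cells (Homo sapiens) for cytotoxicity, read by MTT assay, with a stated time of 72 h; a lower number here means that less compound is tolerated, a higher number that more compound is tolerated.

Compound 1 `CC(C)OC(=O)c1sc(Nc2ncccn2)nc1-c1ccccn1` gives 50000 nM in this assay. Compound 2 `CC(C)OC(=O)c1sc(Nc2ncccn2)nc1-c1cnccn1` differs from it by pyrazin-2-yl in place of pyridin-2-yl on an aromatic carbon and gives 50000 nM; the step of no change at the digits printed from compound 1 to compound 2 (within the scatter) is flat. Compound 3 `CC(C)OC(=O)c1sc(N(COP(=O)(OC(C)(C)C)OC(C)(C)C)c2ncccn2)nc1-c1ccccn1` carries a different core from compound 1; the difference between the two cores is not broken down here. In this assay compound 3 gives 42200 nM, which lies within the scatter of both compound 1 and compound 2, so no ordering among the three measured compounds is claimed.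

Compound 4 `CC(C)OC(=O)c1sc(N(COP(=O)(OC(C)(C)C)OC(C)(C)C)c2ncccn2)nc1-c1cnccn1` is not yet measured. It relates to compound 3 by pyrazin-2-yl in place of pyridin-2-yl on an aromatic carbon. This is the same kind of change as that from compound 1 to compound 2: the group that leaves and the group that enters are identical, and the place is the same carbon of the shared five-membered ring, except that in compound 3 this carbon sits two ring bonds from the ring atom that bears a large group, whereas in compound 1 it sits two ring bonds from the ring atom that bears a (pyrimidin-2-yl)amino group.

Going by the values given here, with only one precedent for the change, the step from compound 3 to compound 4 is expected to be about a 1.1-fold higher number from compound 3 to compound 4 (0.03 log units; within the scatter), resting on the flat step no change at the digits printed from compound 1 to compound 2 (within the scatter) seen between compound 1 and compound 2. On that basis compound 4 is estimated at 45000 nM in this assay, with an expected range from 25000 nM to 60000 nM.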

Compound 4, half-maximal cytotoxic concentration: 50000 nM
The estimate for compound 4 lay 1.1-fold (0.05 log units) below the measured number; the range from low to high includes it.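

In this assay, pyrazin-2-yl in place of pyridin-2-yl on the aromatic carbon gives a 1.2-fold higher number from compound 3 to compound 4 (0.07 log units; within the scatter), so the change again leaves the read-out flat on the second core. Set beside the earlier step, the change reads the same on both cores, with no difference between them that can be told from the scatter: the same change on two cores in this assay, no change at the digits printed (within the scatter) from compound 1 to compound 2 and a 1.2-fold higher number (0.07 log units; within the scatter) from compound 3 to compound 4, 1.2-fold (0.07 log units) apart, within the scatter of two such steps. This supports carrying the change between the core of compound 1 and the core of compound 3 in this one cytotoxicity read-out, but two flat pairs do not show that it would stay flat on a further core or in a different assay, and they give no cause for the flat result.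

The compounds shown leave open whether the same change stays flat once the isopropoxycarbonyl group gives way to a carboxylic acid or to an ester with a longer chain. Going by these compounds alone, they also leave open how the read-out responds when an amine, rather than pyridin-2-yl or pyrazin-2-yl, stands on that aromatic carbon, so the series so far tests only one exchange at one place.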